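Amide to urea on a series that shows only assay limits

The compounds below may be only part of what the source reports. "The series", "measured", "known", "first", "only" and "open" are said of these compounds alone.

Compound 1 `O=C(Nc1cccc(-n2cc(-c3ccncc3)c(-c3ccc(Cl)c(O)c3)n2)c1)Nc1ccc(Cl)c(Cl)c1` gives > 32500 nM in a functional assay on TK-10 cells (Homo sapiens) for inhibition, read by sulforhodamine B assay, with a stated time of 48 h (on this read-out lower numbers stand for higher toxicity in this test and higher numbers for lower toxicity in this test), which is a limit of the assay and not a number.
Compound 2 `COc1cc(-c2nn(-c3cccc(NC(=O)c4ccc(Cl)c(C(F)(F)F)c4)c3)cc2-c2ccncc2)ccc1Cl` gives > 32500 nM in this assay, again a limit.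
Compound 3 `COc1cc(-c2nn(-c3cccc(NC(=O)c4cccc(C(F)(F)F)c4)c3)cc2-c2ccncc2)ccc1Cl` gives > 50000 nM in this assay, also a limit.

Compound 3 therefore stands at the limit of > 50000 nM in this assay, at which 1 of the 3 values shown sits. The other two measured compounds sit at the limit of > 32500 nM in this assay, at which 2 of the 3 values shown sit. For the measured compounds named here, the one step among measured compounds, a step that the two limits leave unreadable from compound 2 to compound 3, is hydrogen in place of chloro on an aromatic carbon, and the two limits leave its size unreadable.

Compound 4 `COc1cc(-c2nn(-c3cccc(NC(=O)Nc4ccc(Cl)c(C(F)(F)F)c4)c3)cc2-c2ccncc2)ccc1Cl` differs from compound 3 by (4-chloro-3-(trifluoromethyl)phenyl)amino in place of 3-(trifluoromethyl)phenyl on a carbonyl carbon. Going by the values given here, no measured step follows this exact change. What the data show is that compound 1, which also carries a urea, sits at a limit, and that compound 3 sits at a limit, so nothing read so far points to toxicity appearing in this assay. The expected step that the limit leaves unreadable from compound 3 to compound 4 is therefore none beyond the scatter, with the result most likely another limit.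

For compound 4 the estimate in this assay is 60000 nM, expected to lie between 20000 nM and 200000 nM.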

Compound 4, concentration lethal to 50% of the cells: > 32500 nM
Compound 4: no number, only a limit (the forecaster's own chance of this, stated with the estimate: 85%); the middle value does not contradict the limit.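

Compound 4 gives > 32500 nM in this assay, a limit of the assay and not a number. Compound 2 and compound 3 also stand at limits, so neither step to compound 4 can be read. The compounds shown leave open whether the urea of compound 4, in place of the amide of compound 2, changes toxicity in this assay at all.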